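A few compounds are considered here, and "the series" means these few. Any claim that something is new, unique, unknown or untested is made for them only; others in the source may bear on it.

Compound 1, `O=C1C=C(NCc2ccccc2)C(=O)c2c1nc1n2[C@H]2OC[C@@H](O)[C@H]2OC1`, carries a benzylamino group on the shared core. In a functional assay on MGC-803 cells (Homo sapiens) for inhibition, read by sulforhodamine B assay (a higher number here means a weaker inhibitor, a lower number a stronger inhibitor), compound 1 gives 2670 nM, the lowest of the two numbers measured here. Its nearest neighbour is compound 2, `CCOc1ccccc1NC1=CC(=O)c2c(nc3n2[C@H]2OC[C@@H](O)[C@H]2OC3)C1=O`, which in this assay gives 2830 nM; the gap between the two lies within the scatter, so they cannot be told apart. Compound 3, `O=C1C(NC2CCCCC2)=CC(=O)c2c1nc1n2[C@H]2OC[C@@H](O)[C@H]2OC1`, carries a cyclohexyl group on the amine nitrogen instead of an aromatic ring. In this assay compound 3 reaches only the limit of > 8000 nM, a limit of the assay rather than a number. The step of an at least 2.8-fold higher number from compound 2 to compound 3 (0.45 log units; beyond the scatter) shows that replacing the aromatic ring with a saturated ring weakens inhibition, by an amount whose true size stays hidden behind the limit.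

Compound 4, `O=C1C=C(N2CCC2)C(=O)c2c1nc1n2[C@H]2OC[C@@H](O)[C@H]2OC1`, is not yet measured. It differs from compound 1 by azetidin-1-yl in place of benzylamino on a double-bonded ring carbon. Among the compounds with values here, the only measured step that bears on this change is an at least 2.8-fold higher number from compound 2 to compound 3 (0.45 log units; beyond the scatter), where an aromatic ring gave way to a saturated one and the number rose to the limit. Azetidin-1-yl likewise brings a saturated ring and no aromatic ring. A rise beyond the scatter is therefore expected, of a size a 2.6-fold higher number from compound 1 to compound 4 (0.42 log units; beyond the scatter), with a real chance that only the limit is reported, as seen at the limit of > 8000 nM in this assay, at which 1 of the 3 values shown sits. The expected value for compound 4 in this assay is 7000 nM, between 2500 nM and 20000 nM.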

Compound 4, half-maximal inhibitory concentration: > 16000 nM
Compound 4 was reported as a limit (the forecaster's own chance of this, stated with the estimate: 40%); middle value at least 2.2-fold (0.35 log units) from the limit.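

Azetidin-1-yl in place of benzylamino on this double-bonded ring carbon gives an at least 5.9-fold higher number from compound 1 to compound 4 (0.77 log units; beyond the scatter), so in this assay this position does not accept every nitrogen-linked group equally. Unlike the earlier change, which kept the hydrogen on the amine nitrogen, this one also removes that hydrogen: benzylamino has 1 hydrogen-bond donor and azetidin-1-yl has 0, while the aromatic ring disappears and the group shrinks from 8 heavy atoms to 4, all in a single step. Compound 4 is reported only as a limit, so the real size of the loss stays hidden: the limit of > 16000 nM in this assay, at which 1 of the 4 values shown sits.

Which of these three differences accounts for the loss stays open, as all of them arrive together in the one step. A benzyl(methyl)amino group would keep the aromatic ring without the amine hydrogen, and a cyclobutylamino group would keep the amine hydrogen on a small saturated ring, so the two could begin to pull these differences apart.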